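The compounds below may be only part of what the source reports. "The series", "measured", "known", "first", "only" and "open" are said of these compounds alone.

The measured compounds:

compound 1, `COc1cc(/C=C/C(=O)c2ccc(OC)c([N+](=O)[O-])c2)cc(OC)c1`: 5600 nM
compound 2, `COc1cc(/C=C/C(=O)c2ccc(OC)c(N)c2)cc(OC)c1`: 8800 nM
compound 3, `COc1ccc(OC)c(C(=O)/C=C/c2ccc([N+](=O)[O-])cc2)c1`: > 100000 nM

All three were tested in a functional assay on B16 cells (Mus musculus) for cytotoxicity, read by MTT assay, with a stated time of 3 days; a lower number here means a stronger inhibitor, a higher number a weaker inhibitor. Compound 1 gives 5600 nM and compound 2 gives 8800 nM; the step between them is a 1.6-fold higher number from compound 1 to compound 2 (0.20 log units; within the scatter), and the change behind it is amino in place of nitro on an aromatic carbon. Compound 3 reaches only a limit in this assay, namely > 100000 nM. The difference between the core of compound 3 and the core of compound 1 is not broken down here. Going by the values given here, the one fixed point for compound 3 is the limit of > 100000 nM in this assay, at which 1 of the 3 values shown sits.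

Compound 4, `COc1ccc(OC)c(C(=O)/C=C/c2ccc(N)cc2)c1`, has not yet been measured. It differs from compound 3 by amino in place of nitro on an aromatic carbon. Among the compounds with values here, this is the same kind of change as the one from compound 1 to compound 2, but the surroundings differ: there the amino sat ortho to a methoxy group and meta to a large group, here it sits para to a large group.

For compound 4 the step is expected to be about a number no higher from compound 3 to compound 4 (the limit leaves the size open), since the measured step of a 1.6-fold higher number from compound 1 to compound 2 (0.20 log units; within the scatter) lay within the scatter. Compound 4 is therefore estimated at about 100000 nM, between 30000 nM and 300000 nM, most likely again only a limit.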

Compound 4, half-maximal inhibitory concentration: > 100000 nM
Compound 4 was reported as a limit (the forecaster's own chance of this, stated with the estimate: 70%); the middle value lies on the limit itself.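

Compound 3 and compound 4 are both reported only as limits, so no step can be read between them: the limit of > 100000 nM in this assay, at which 2 of the 4 values shown sit.

The compounds shown leave open what the actual values of compound 3 and compound 4 are, and so whether amino in place of nitro changes the number at all on the core of compound 3.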